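Swapping the Hydroxyethyl Side Chain for Aminomethyl

A few compounds are considered here, and "the series" means these few. Any claim that something is new, unique, unknown or untested is made for them only; others in the source may bear on it.

Measured compounds:
Compound 1, `C[C@H](O)[C@H]1C(=O)N2C(C(=O)O)=C(C(C)(C)C)O[C@H]12`, in an ADME assay, in phosphate buffer, at 28 degrees C, at pH 7.0 (on this read-out lower numbers stand for a shorter-lived compound and higher numbers for a longer-lived compound), gives 7.1 h.
Compound 2, `CC(C)(C)C1=C(C(=O)O)N2C(=O)[C@H]([C@@H](O)c3ccc(O)cc3)[C@H]2O1`, in this assay gives 10.3 h.

For the measured compounds named here, compound 1 sits at the lower end of these two numbers, but its only neighbour, compound 2, lies within the usual scatter of it, so the two are not distinguished. Going by the values given here, the one measured step is a 1.5-fold higher number from compound 1 to compound 2 (0.16 log units; within the scatter); it changes the far end of the side chain while keeping the hydroxyl-bearing carbon in place.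

Compound 3, `CC(C)(C)C1=C(C(=O)O)N2C(=O)[C@H](CN)[C@H]2O1`, differs from compound 1 in this way: aminomethyl in place of 1-hydroxyethyl on a saturated ring carbon. Among the compounds with values here, this removes the whole 1-hydroxyethyl group rather than extending it, and no measured pair shows such a swap. Within the data shown here, the only guidance comes from compound 2, whose step a 1.5-fold higher number from compound 1 to compound 2 (0.16 log units; within the scatter) at this same side chain stayed within the scatter. On that basis the step of a 1.0-fold lower number from compound 1 to compound 3 (0.01 log units; within the scatter) is expected to be none beyond the scatter, in either direction. Compound 3 is therefore estimated at 7 h in this assay, with a range from 3.5 h to 14 h.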

Compound 3, half-life: 1.2 h
Compound 3: middle estimate off by 5.8-fold (0.77 log units), on the high side; the measured number lies below the stated range.
By their numbers in this assay, from the lowest: compound 3; then compounds 1 and 2 (each within the scatter of the next).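

In this assay, the side chain on this saturated ring carbon proves not to be indifferent to change: the swap to aminomethyl gives a 5.9-fold lower number from compound 1 to compound 3 (0.77 log units; beyond the scatter), whereas the earlier change at the far end of the side chain, which kept the hydroxyl-bearing carbon in place, gave only a 1.5-fold higher number from compound 1 to compound 2 (0.16 log units; within the scatter). The groups that leave and enter have the same counts of hydrogen-bond donors and acceptors, and neither carries a net charge, so these counts do not separate them; they differ in having a nitrogen in place of an oxygen, fewer heavy atoms and no defined stereocentre on the entering group. Nothing available explains why the number falls with this swap.

Because these differences arrive together, the compounds shown leave open whether the shorter half-life goes with the amine nitrogen, the loss of the hydroxyl-bearing carbon or the smaller side chain. A hydroxymethyl group would keep the oxygen on a chain of aminomethyl's size, and a 1-aminoethyl group would place the nitrogen on a chain of 1-hydroxyethyl's size, so the two could begin to pull these differences apart.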